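Substituent swap on the anilino ring, compound 4

The compounds below may be only part of what the source reports. "The series", "measured", "known", "first", "only" and "open" are said of these compounds alone.

The three measured compounds share one core and differ only in the aryl group on a nitrogen on an aromatic ring. Compound 1 `C=CC(=O)Nc1cccc(NC(=O)CSc2nc(Nc3ccccc3F)c3ccccc3n2)c1` in a functional assay on MDA-MB-231 cells (Homo sapiens) for inhibition, read by MTT assay, with a stated time of 72 h (a higher number here means a weaker inhibitor, a lower number a stronger inhibitor), gives 18700 nM. Compound 2 `C=CC(=O)Nc1cccc(NC(=O)CSc2nc(Nc3ccc(F)cc3)c3ccccc3n2)c1` gives 9490 nM, and compound 3 `C=CC(=O)Nc1cccc(NC(=O)CSc2nc(Nc3ccc(C(F)(F)F)cc3)c3ccccc3n2)c1` gives 11500 nM. Compound 3 stands second highest of the three numbers; its nearest neighbour is compound 2, and its furthest is compound 1, yet every gap among the three lies within the scatter, so no order can be read from them.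

Compound 4 `C=CC(=O)Nc1cccc(NC(=O)CSc2nc(Nc3ccc(CC)cc3)c3ccccc3n2)c1` is not yet measured. The change is ethyl in place of trifluoromethyl on an aromatic carbon. Among the compounds with values here, the one measured step at the same position is a 1.2-fold higher number from compound 2 to compound 3 (0.08 log units; within the scatter), which stayed within the scatter. The two moves from the 2-fluorophenyl compound, a 2.0-fold lower number from compound 1 to compound 2 (0.29 log units; within the scatter) and a 1.6-fold lower number from compound 1 to compound 3 (0.21 log units; within the scatter), also stayed within the scatter. Nothing measured here separates one substituent at this position from another, so for compound 4 no step beyond the scatter is expected in this assay in either direction; the expected step is a 1.0-fold lower number from compound 3 to compound 4 (0.02 log units; within the scatter). Compound 4 is therefore estimated to give about 11000 nM, with a range from 5000 nM to 25000 nM.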

Compound 4, half-maximal inhibitory concentration: 14400 nM
Beside the measured number, compound 4's estimate is 1.3-fold (0.12 log units) below it; low and high end bracket the measured number.
By their numbers in this assay, from the lowest: compounds 2, 3, 4 and 1 (each within the scatter of the next).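

Replacing trifluoromethyl with ethyl removes all the fluorine from this substituent and leaves it with fewer heavy atoms, yet the result in this assay stays within the scatter (a 1.3-fold higher number from compound 3 to compound 4 (0.10 log units; within the scatter)). Set against fluoro at the same aromatic carbon, ethyl also gives no separable difference (a 1.5-fold higher number from compound 2 to compound 4 (0.18 log units; within the scatter)), and the same holds for the whole 4-ethylphenyl group against 2-fluorophenyl on the nitrogen (a 1.3-fold lower number from compound 1 to compound 4 (0.11 log units; within the scatter)), so a carbon-only substituent now joins the two fluorinated ones with no step beyond the scatter in this series of four compounds. No independent data bear on why these numbers lie so close together.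

Still open, as far as these compounds go, is whether any group at this aromatic carbon can produce a step beyond the scatter, for example an amine, a carboxylic acid, a hydroxyl or a longer chain such as n-butyl, since the three substituents here are all uncharged and carry no hydrogen-bond donors or acceptors. Also open, from the compounds shown here alone, is how the numbers respond to changes outside the aryl group, as all four compounds keep the rest of the shared core unchanged.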